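From Branched Group to Small Ring at the Triple Bond

The compounds below may be only part of what the source reports. "The series", "measured", "known", "first", "only" and "open" are said of these compounds alone.

Going by the values given here, in an in vitro ADME assay on microsomes from liver (Rattus norvegicus) for metabolic stability, tested at 2 uM (a higher number here means that the compound lasts longer, a lower number that the compound disappears faster), compound 1 `O=C(O)C#Cc1ccc(NC(=O)CSc2nnnn2-c2ccc(C3CC3)cc2Cl)c(Cl)c1` gives 0.333 h and compound 2 `CC(C)(C#Cc1ccc(NC(=O)CSc2nnnn2-c2ccc(C3CC3)cc2Cl)c(Cl)c1)C(=O)O` gives 1.5 h, the higher of the two numbers so far. The next compound, compound 3 `O=C(CSc1nnnn1-c1ccc(C2CC2)cc1Cl)Nc1ccc(C#CC2(C(=O)O)CC2)cc1Cl`, keeps the shared core and alters a single group: 1-carboxycyclopropyl in place of 1-carboxy-1-methylethyl on a triple-bonded carbon. In words, 1-carboxycyclopropyl stands in place of 1-carboxy-1-methylethyl on a triple-bonded carbon, so the new group carries a three-membered ring of carbon only.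

Just one measured step bears on this place in the molecule: a 4.5-fold higher number from compound 1 to compound 2 (0.65 log units; beyond the scatter). That modest step, beyond the scatter, came when 1-carboxy-1-methylethyl replaced a bare carboxy group. Among the compounds with values here, it shows that a change here can move the half-life, but no measurement yet shows what a ring does. The coming change is a milder edit, since a carboxy-bearing group of the same size stays in place, so no clear direction can be called. The estimated change is a 1.2-fold lower number from compound 2 to compound 3 (0.06 log units; within the scatter), expected to stay within the scatter. For compound 3 the expected half-life is 1.3 h, with an estimated range from 0.6 h to 3 h.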

Compound 3, half-life: 0.5 h
Estimate against measurement, compound 3: 2.6-fold (0.41 log units) above, and the stated range ends above it.
By their numbers in this assay, from the lowest: compounds 1 and 3 (each within the scatter of the next); then compound 2.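

Although 1-carboxycyclopropyl and 1-carboxy-1-methylethyl match in their heavy atoms and in their hydrogen-bond donors and acceptors, the swap in this assay gives a 3.0-fold lower number from compound 2 to compound 3 (0.48 log units; beyond the scatter). The number at this triple-bonded carbon therefore responds to the shape of the group, ring or no ring, even when its atom counts stay the same, and the rise seen in a 4.5-fold higher number from compound 1 to compound 2 (0.65 log units; beyond the scatter) does not carry over to every group that holds a carboxy here: the ring version gives a 1.5-fold higher number from compound 1 to compound 3 (0.18 log units; within the scatter), which leaves compound 2 as the only one of the three that stands clearly apart. Nothing measured on these compounds speaks to why the ring and the branched group differ.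

The compounds shown leave open whether a larger ring, such as 1-carboxycyclobutyl, would track compound 2 or compound 3, and so whether this result belongs to the three-membered ring alone. They also leave open how the half-life would respond at this place if a primary amide or a hydroxymethyl group took over from the carboxy on the same branched or ring-bearing carbon.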